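The source may hold more compounds than are shown below. What is called first, only, known or untested is meant among the compounds shown, and "the series" means these compounds.

Compound 1 `Cc1cc(C)cc(N2CCNC(=O)N2)c1`: in an assay on RBL-1 cells for inhibition of Polyunsaturated fatty acid 5-lipoxygenase (Rattus norvegicus) (on this read-out higher numbers stand for weaker inhibition and lower numbers for stronger inhibition), compound 1 gives 12000 nM.
Compound 2 `CCN1CCN(c2ccccc2)NC1=O`: in this assay compound 2 gives 32000 nM.

Of these two numbers, compound 2 stands highest; compound 1 gives the lower number, and the gap between them lies beyond the usual scatter of repeated measurements. Compound 3 `O=C1NN(c2ccccc2)CCN1Cc1ccccc1` has not yet been measured in this assay. It differs from compound 2 in one place only: phenyl in place of methyl on a saturated chain carbon bound to an amide-type nitrogen in a ring. Within the data shown here, no step of this kind between measured compounds is available here, so the direction and size must be judged from the structural change itself. The expectation for compound 3 is a modest move toward a lower number, a step of a 2.1-fold lower number from compound 2 to compound 3 (0.33 log units; beyond the scatter), which may well stay within the scatter rather than beyond it. For compound 3 the estimated value in this assay is 15000 nM, with a range from 5000 nM to 50000 nM.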

Compound 3, half-maximal inhibitory concentration: 8300 nM
The estimate for compound 3 lay 1.8-fold (0.26 log units) above the measured number; low and high end bracket the measured number.
By their numbers in this assay, from the lowest: compounds 3 and 1 (each within the scatter of the next); then compound 2.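

In this assay, among these compounds, phenyl in place of methyl on a saturated chain carbon bound to an amide-type nitrogen in a ring gives a 3.9-fold lower number from compound 2 to compound 3 (0.59 log units; beyond the scatter) and so provides the first reading of this change. The step is modest but lies beyond the scatter, showing that this position tolerates the larger group and that inhibition becomes stronger with it. Nothing at hand accounts for the size or direction of this step.

The compounds shown leave open how a longer chain, an amine or a carboxylic acid at this place would compare with phenyl and methyl. They also leave open whether the same change would give a similar step on another core, such as the core of compound 1.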